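Urea variant of compound 1: expected antiproliferative read-out

A few compounds are considered here, and "the series" means these few. Any claim that something is new, unique, unknown or untested is made for them only; others in the source may bear on it.

Measured so far:
- compound 1, `O=C(Nc1ccc(-n2ccc3c(NC(=O)c4ccccc4)ncnc32)cc1)c1ccc(Cl)c(C(F)(F)F)c1`: 5500 nM
- compound 2, `CC(=O)Nc1ncnc2c1ccn2-c1ccc(NC(=O)c2ccc(Cl)c(C(F)(F)F)c2)cc1`: > 10000 nM

In an ADME assay on HS27 cells (Homo sapiens) for antiproliferative activity, read by MTT assay, with a stated time of 24 h (on this read-out lower numbers stand for stronger inhibition and higher numbers for weaker inhibition), compound 1 gives 5500 nM. Going by the values given here, this is the only numerical value in the set. For compound 2 the result is a limit of the assay, > 10000 nM, not a number; see (the limit of > 10000 nM in this assay, at which 1 of the 2 values shown sits). Among the compounds with values here, the one measured step, an at least 1.8-fold higher number from compound 1 to compound 2 (0.25 log units; that floor lies within the scatter), concerns the group on the carbonyl carbon of the benzamide at the core and has a floor within the scatter, so nothing firm follows from it.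

Compound 3, `O=C(Nc1ccc(-n2ccc3c(NC(=O)c4ccccc4)ncnc32)cc1)Nc1ccc(Cl)c(Cl)c1`, differs from compound 1 elsewhere: (3,4-dichlorophenyl)amino in place of 4-chloro-3-(trifluoromethyl)phenyl on a carbonyl carbon, which turns the aryl amide into a urea. Within the data shown here, no measured step touches this position, so no direction can be read from the data. The expectation for compound 3 is therefore a value near that of compound 1, with a wide range, 5500 nM (1800 nM to 16000 nM), which means an expected step of no change at the digits printed from compound 1 to compound 3 (within the scatter). The estimate is provisional until compound 3 is measured in this assay.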

Compound 3, half-maximal inhibitory concentration: 4500 nM
Beside the measured number, compound 3's estimate is 1.2-fold (0.09 log units) above it; the range from low to high includes it.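

In this assay, (3,4-dichlorophenyl)amino can stand in place of 4-chloro-3-(trifluoromethyl)phenyl on the carbonyl carbon, turning the aryl amide into a urea, with a 1.2-fold lower number from compound 1 to compound 3 (0.09 log units; within the scatter). Going by these compounds alone, this is the first step at this position and the first with a number at both ends, and it shows that the read-outs of the amide and the urea cannot be told apart, even though the entering group carries one hydrogen-bond donor and the leaving group none. Nothing in the data shown offers a reason for this result.

On these data alone, the step replaces the link to the ring and the ring substituents in a single move, so it remains open whether each alone would leave the read-out as it stands or whether their contributions offset each other, a question that a urea bearing 4-chloro-3-(trifluoromethyl)phenyl could address. Also open, as far as these compounds go, is how this assay responds when the aryl ring at this place gives way to a non-aromatic group, such as a saturated amine or a carboxylic acid.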